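Swapping the aryl group on a shared quinolinone-type core

This account rests on a few compounds, and the source may have more. Where it says the series, first, only, none or still open, it means among the compounds named here.

Measured so far:
compound 1, `Cc1cc(-c2c(O)nc3cc(Cl)c([N+](=O)[O-])cc3c2OCCC2CCCCN2)cc(C(C)O)c1`: 63 nM
compound 2, `O=C(Nc1cc2c(OCCC3CCCCN3)c(-c3cccc(Br)c3)c(O)nc2cc1Cl)NC1CC1`: 6 nM
compound 3, `Cc1cc(C)cc(-c2c(O)nc3cc(Cl)c(NC(=O)Nc4ncccn4)cc3c2OCCC2CCCCN2)c1`: 6 nM

Of the compounds shown here, three built on the same core have been tested in a functional assay on cells (Pituitary gland cell) for antagonist activity at Gonadotropin-releasing hormone receptor (Rattus norvegicus); a higher number here means a weaker inhibitor, a lower number a stronger inhibitor. Compound 1 stands at the high end of this small set: its number is the highest of the three, and both compound 2 and compound 3 lie well below it, each by a step beyond the usual scatter. Compound 2 and compound 3 differ from compound 1 in more than one place at once, so no single change can be credited for their lower numbers.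

Compound 4, `O=[N+]([O-])c1cc2c(OCCC3CCCCN3)c(-c3cccc(F)c3)c(O)nc2cc1Cl`, has not yet been measured. It keeps the nitro group and the rest of the core of compound 1 and changes only the aryl substituent: 3-fluorophenyl in place of 3-(1-hydroxyethyl)-5-methylphenyl on an aromatic carbon. The 3-fluorophenyl group has no hydrogen-bond donor or acceptor, whereas the group it replaces carries one of each.

Nothing in the data isolates the effect of this aryl swap on its own, so the expectation rests on the general closeness of these analogues. A modest step from compound 1 to compound 4 of a 1.6-fold lower number from compound 1 to compound 4 (0.20 log units; within the scatter) is expected, likely toward a somewhat lower number. Compound 4 is estimated to give 40 nM, within a range from 12 nM to 130 nM.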

Compound 4, half-maximal inhibitory concentration: 53 nM
For compound 4 the middle estimate is 1.3-fold (0.12 log units) below the measured one; the measured number falls inside the stated range.
By their numbers in this assay, from the lowest: compounds 2 and 3 (each within the scatter of the next); then compounds 4 and 1 (each within the scatter of the next).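

In this assay, within the data shown here, compound 1 and compound 4 differ in one place only, which makes this the one pair in the set where a single change can be read. With the nitro group and the rest of the shared core held fixed, putting 3-fluorophenyl in place of 3-(1-hydroxyethyl)-5-methylphenyl gives a 1.2-fold lower number from compound 1 to compound 4 (0.08 log units; within the scatter) and so no real difference between the two compounds. The group that leaves carries a hydrogen-bond donor and acceptor and the group that enters carries neither, yet for this pair that exchange leaves the number within the usual scatter, and no measurement shown here offers an explanation.

This single pair cannot say whether other groups on this aromatic carbon would behave the same way, for instance a phenyl ring bearing a carboxylic acid or an aminomethyl group. On these data alone, compound 2 and compound 3 differ from compound 1 and compound 4 in more than one place, so it also remains open how much of their lower numbers belongs to the group standing where the nitro group sits and how much to the aryl group.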